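The source may hold more compounds than are shown below. What is called first, only, known or untested is meant among the compounds shown, and "the series" means these compounds.

In a physicochemical assay for metabolic stability, read by HPLC, in phosphate buffer, at pH 7.4, tested at 10 uM (on this read-out lower numbers stand for a shorter-lived compound and higher numbers for a longer-lived compound), compound 3 `Cc1nc2ccccc2n1C(=O)NCCCCc1ccccc1` gives 0.117 h. Compound 1 `Cc1ccccc1CNC(=O)n1c(N)nc2ccccc21` gives 0.167 h, and the gap between the two lies within the scatter, so neither can be set above the other. Compound 2 `COc1nc2ccccc2n1C(=O)NCCCCc1ccccc1` reaches > 2 h, which is a limit of this assay rather than a number. Going by the values given here, only one measured step touches the same aromatic carbon: an at least 17-fold lower number from compound 2 to compound 3 (1.23 log units; beyond the scatter), so the group at this carbon can move the half-life strongly. Compound 4 `Nc1nc2ccccc2n1C(=O)NCCCCc1ccccc1` carries amino in place of methyl on an aromatic carbon. Among the compounds with values here, no measured step covers amino against methyl directly. Compound 1 bears amino with a different chain and sits close to compound 3. A step of a 1.7-fold higher number from compound 3 to compound 4 (0.23 log units; within the scatter) is therefore expected, nothing beyond the scatter. Compound 4 is estimated at 0.2 h, between 0.08 h and 0.6 h.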

Compound 4, half-life: 0.233 h
The estimate for compound 4 lay 1.2-fold (0.07 log units) below the measured number; low and high end bracket the measured number.
By their numbers in this assay, from the lowest: compounds 3, 1 and 4 (each within the scatter of the next). At a limit, above all of these: compound 2.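

In this assay, amino in place of methyl gives a 2.0-fold higher number from compound 3 to compound 4 (0.30 log units; within the scatter), so these two groups at this carbon cannot be told apart. Amino in place of methoxy gives an at least 8.5-fold lower number from compound 2 to compound 4 (0.93 log units; beyond the scatter), so among the three groups shown, methoxy alone stands apart, with the longer half-life. The entry for compound 2 is a limit and not a number: the limit of > 2 h in this assay, at which 1 of the 4 values shown sits.

The compounds shown leave open how far compound 2 truly lies from the other two. They also leave open whether ethoxy or dimethylamino at this carbon would behave like methoxy or like amino.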